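This account rests on a few compounds, and the source may have more. Where it says the series, first, only, none or still open, it means among the compounds named here.

Working notes on the series built around the core of compound 1 `CC(C)(C)OC(=O)NCCC[C@@H]1N=C2C[C@@H]3C[C@@H](C3(C)C)[C@]2(C)OC1=O`. In a functional assay on PC-3 cells (Homo sapiens) for antiproliferative activity, read by sulforhodamine B assay, with a stated time of 48 h (a lower number here means a stronger inhibitor, a higher number a weaker inhibitor), compound 1 gives 6600 nM, the lowest of the three numbers measured. For the measured compounds named here, compound 3 `CC(C)(C)OC(=O)NCCCC[C@@H]1N=C2C[C@@H]3C[C@@H](C3(C)C)[C@]2(C)OC1=O` gives 18000 nM in this assay, and the step of a 2.7-fold higher number from compound 1 to compound 3 (0.44 log units; beyond the scatter) is the only single-point change measured so far, a lengthening of the chain. Compound 2 `CC1(C)N=C2C[C@H]3C[C@H](C3(C)C)[C@@]2(C)OC1=O` gives 166000 nM in this assay and stands furthest from compound 1 of the measured set.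

Compound 4 `CC(C)(C)OC(=O)NCCC[C@H]1N=C2C[C@H]3C[C@H](C3(C)C)[C@@]2(C)OC1=O` is the next candidate. The change from compound 1: the two compounds have the same atoms and bonds and differ only in configuration as drawn: 4 of 4 stereo elements differ (all stereocentres are inverted: mirror images); a stereocentre at a saturated ring carbon is drawn S in compound 1 and R in compound 4; a stereocentre at a saturated ring carbon is drawn S in compound 1 and R in compound 4; a stereocentre at a saturated ring carbon is drawn S in compound 1 and R in compound 4; a stereocentre at a saturated ring carbon is drawn S in compound 1 and R in compound 4. Going by the values given here, no measured pair in the set separates configuration from constitution, so the chain step from compound 1 to compound 3 and the comparison with compound 2 do not bear on this change; neither direction nor size can be read from what is in hand. Inversion of every stereocentre has no precedent here, so some loss relative to compound 1 is expected, but with wide uncertainty. Compound 4 is therefore estimated at 20000 nM, between 4000 nM and 120000 nM. The expected step is a 3.0-fold higher number from compound 1 to compound 4 (0.48 log units; beyond the scatter).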

Compound 4, half-maximal inhibitory concentration: 60000 nM
Estimate against measurement, compound 4: 3.0-fold (0.48 log units) below, within the range that was stated.
By their numbers in this assay, from the lowest: compound 1; then compound 3; then compound 4; then compound 2.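

In this assay, for the compounds shown here, the step is a 9.1-fold higher number from compound 1 to compound 4 (0.96 log units; beyond the scatter), and this is the first measured pair that separates configuration from constitution. Compound 1 and its mirror image therefore give clearly different numbers, so antiproliferative activity in this series depends on configuration as well as on the chain. The step can be ascribed to configuration as drawn, because nothing else separates the pair: the fact that compounds 1 and 4 differ only in the configuration as drawn

The compounds shown do not tell which of the four stereocentres carries the step, as all four are inverted together, or whether the mirror image of compound 3 would follow the same direction. Also open, going by these compounds, is how the chain would behave with a free primary amine or a carboxylic acid in place of the (tert-butoxycarbonyl)amino group.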